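Moving the pyrazole attachment on a chloro-bearing core

A few compounds are considered here, and "the series" means these few. Any claim that something is new, unique, unknown or untested is made for them only; others in the source may bear on it.

Compound 2 `Clc1ccc2c(c1-c1ccn[nH]1)CCC2c1ncc[nH]1` has been tested in a functional assay on CHO cells for agonist activity at Alpha-1B adrenergic receptor (Homo sapiens), read by FLIPR and calcium flux; a lower number here means that less compound is needed, a higher number that more compound is needed for the effect. For compound 2 the assay reports no number but only a limit, > 10000 nM. This is the limit of > 10000 nM in this assay, at which 1 of the 3 values shown sits.

Two measured relatives frame this result. Compound 1 `c1cc(-c2ccn[nH]2)c2c(c1)C(c1ncc[nH]1)CC2` carries a hydrogen where compound 2 carries its chloro group; in this assay compound 1 gives 600 nM. Going by the values given here, the single measured step is an at least 16-fold higher number from compound 1 to compound 2 (1.22 log units; beyond the scatter), so adding the chloro group alone pushed the compound out of the measurable range. Compound 3 `c1ccc2c(c1)CCCC2c1ncc[nH]1` lacks both the chloro group and the pyrazole; in this assay compound 3 gives 791 nM, close to compound 1.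

Compound 4 `Clc1ccc2c(c1-c1cn[nH]c1)CCC2c1ncc[nH]1` is not yet measured. It keeps the chloro group of compound 2 and differs only in how the pyrazole is attached: 1H-pyrazol-4-yl in place of 1H-pyrazol-5-yl on an aromatic carbon. Among the compounds with values here, no measured step involves a change of this kind, so none bears directly on it; the one step that is known concerns the chloro group, which compound 4 retains. The expectation therefore is that compound 4 stays near the limit, with no step beyond the scatter, expressed as a number no higher from compound 2 to compound 4 (the limit leaves the size open). Compound 4 is estimated at 10000 nM, within a range from 3000 nM to 30000 nM.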

Compound 4, half-maximal effective concentration: > 10000 nM
Compound 4 ended at the assay's limit; the forecaster's own chance of this, stated with the estimate: 55%; the middle value lies on the limit itself.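

Going by these compounds alone, compound 4 ends at a limit and not at a number, just as compound 2 does, so no step from one to the other can be read: the limit of > 10000 nM in this assay, at which 2 of the 4 values shown sit.

The compounds shown leave open how far each lies past that limit, and so whether 1H-pyrazol-4-yl in place of 1H-pyrazol-5-yl changes the number at all.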